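Halogen swap on the aryl ring of the shared core

A few compounds are considered here, and "the series" means these few. Any claim that something is new, unique, unknown or untested is made for them only; others in the source may bear on it.

The series is followed in a functional assay on PC-9 cells (Homo sapiens) for antiproliferative activity, read by MTT assay; a lower number here means a stronger inhibitor, a higher number a weaker inhibitor. Compound 1 `C#CCSc1nc(Sc2nc3ccccc3s2)c(C#N)c(-c2cc(OC)c(OC)c(OC)c2)n1` gives only a limit there, > 20000 nM, which is not a number. That limit is the limit of > 20000 nM in this assay, at which 1 of the 3 values shown sits. Compound 2 `C=CC(=O)Nc1ccccc1CN(C(=O)Nc1cccc(C(F)(F)F)c1)C1CCN(C(C)CCC)CC1` gives 5590 nM. Compound 3 `C#CCSc1nc(Sc2nccs2)c(C#N)c(-c2ccc(Br)cc2)n1` gives 12100 nM, the highest of the two numbers recorded; its nearest neighbour is compound 2, whose number is lower by a margin beyond the usual scatter. Among the measured compounds shown here, no pair of measured compounds differs in a single place, so no measured step is available for comparison.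

Compound 4 `C#CCSc1nc(Sc2nccs2)c(C#N)c(-c2ccc(Cl)cc2)n1` is not yet measured. It differs from compound 3 by chloro in place of bromo on an aromatic carbon: the 4-bromophenyl becomes a 4-chlorophenyl, the exchange sitting on an aromatic carbon of a six-membered aromatic ring of carbon only, para to a large group. The measured compounds give no guide to how this assay responds to this exchange. The step expected from compound 3 to compound 4 is a 1.2-fold higher number from compound 3 to compound 4 (0.06 log units; within the scatter), small and within the usual scatter. Compound 4 is therefore expected to give about 14000 nM in this assay, estimated between 6000 nM and 30000 nM, with a fair chance that only a limit is reported.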

Compound 4, half-maximal inhibitory concentration: 4130 nM
Compound 4: middle estimate off by 3.4-fold (0.53 log units), on the high side; the whole stated range lies above it.
By their numbers in this assay, from the lowest: compounds 4 and 2 (each within the scatter of the next); then compound 3. At a limit, above all of these: compound 1.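

The position on the aromatic carbon, para to a large group, responds to a single halogen exchange: in this assay, chloro in place of bromo gives a 2.9-fold lower number from compound 3 to compound 4 (0.47 log units; beyond the scatter), a modest step but one beyond the scatter. Among the compounds shown here, this is the first measured step, and it shows that the shared core carrying the 4-bromophenyl can be improved by a change at this one place, with compound 4 reaching 4130 nM in this assay. Nothing among the measurements at hand explains why the 4-chlorophenyl gives the lower number.

From the compounds shown here alone, two halogens make no trend, so how fluoro or a methyl group at the same place would read in this assay remains open. Also open, going by these compounds, is whether this exchange gives a step of similar size when the rest of the shared core is changed, and whether an amine or a carboxylic acid at this position would move the number further in either direction.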